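The source may hold more compounds than are shown below. What is called first, only, known or untested is meant among the compounds shown, and "the series" means these compounds.

Compound 3 `Cc1ccccc1C(=O)NC(CCN(C)C)c1ccc(Cl)cc1` gives 3550 nM in an assay on NIH3T3 cells with Urotensin-2 receptor (Homo sapiens) as the target (on this read-out lower numbers stand for an effect already at smaller amounts and higher numbers for an effect only at larger amounts of compound), the highest of the three numbers measured. Compound 1 `Cc1ccsc1C(=O)OC(CCN(C)C)c1ccc(Cl)cc1` gives 2510 nM in this assay, which lies within the scatter of compound 3, while compound 2 `Cc1c(Cl)cccc1C(=O)OC(CCN(C)C)c1ccc(Cl)cc1` gives 1120 nM, a number beyond the scatter below compound 3. The only measured step among these compounds is a 2.2-fold lower number from compound 1 to compound 2 (0.35 log units; beyond the scatter), and it exchanges the whole ring on the carbonyl carbon rather than a single substituent.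

Compound 4 `CN(C)CCC(NC(=O)c1ccccc1)c1ccc(Cl)cc1` differs from compound 3 by hydrogen in place of methyl on an aromatic carbon. Among the measured compounds shown here, no measured pair isolates the loss of a methyl from the ring on the carbonyl carbon, so the single step on record bears on this change only loosely and gives no direction. The expected step is therefore a 1.1-fold higher number from compound 3 to compound 4 (0.05 log units; within the scatter), roughly within the scatter of compound 3. On that footing compound 4 is estimated to give 4000 nM in this assay, with a range from 1500 nM to 11000 nM.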

Compound 4, half-maximal effective concentration: 1410 nM
Compound 4: the middle estimate sits 2.8-fold (0.45 log units) above what was measured; the measured number lies below the stated range.
By their numbers in this assay, from the lowest: compounds 2, 4, 1 and 3 (each within the scatter of the next, the first and the last beyond it).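

In this assay, the change from 2-methylphenyl to phenyl gives a 2.5-fold lower number from compound 3 to compound 4 (0.40 log units; beyond the scatter), so removing the methyl from this place, ortho to a large group, moves the number lower rather than higher. Where the earlier step exchanged a whole ring on the carbonyl carbon, this one removes a single methyl, and it shows that the methyl is not required for activity in this compound with nitrogen on the carbonyl. Nothing available here accounts for the shift.

As far as these compounds go, whether losing the methyl would have the same effect with oxygen on the carbonyl in place of nitrogen remains open, since the two compounds with that oxygen both keep a methyl on their rings. Also open, from the compounds shown here alone, is how a fluorine, a methoxy or a hydroxyl at this place would compare with hydrogen.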